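The source may hold more compounds than are shown below. What is called first, only, known or untested is meant among the compounds shown, and "the series" means these compounds.

The series is built on a shared core carrying a bicyclic aromatic group on the sulfonyl sulfur of a sulfonamide. Compound 1, `O=C1[C@@H](NS(=O)(=O)c2cc3ncccc3s2)CCN1Cc1cc2c[nH]ccc-2n1`, gives 61% in an assay on isolated protein for inhibition of coagulation factor X (Oryctolagus cuniculus), tested at 1 uM; a higher number here means more inhibition at the concentration tested (going by the name of the read-out), a lower number less inhibition. Among the measured compounds shown here, compound 2, `O=C1[C@@H](NS(=O)(=O)c2cc3c(Cl)nccc3s2)CCN1Cc1cc2c[nH]ccc-2n1`, gives 35% in this assay; this is the lowest of the two numbers measured so far, and the only recorded step, a number 26 percentage points lower from compound 1 to compound 2 (beyond the scatter), goes with the group of 10 heavy atoms carrying chlorine entering in place of the group of 9 heavy atoms without it. Compound 3, `O=C1[C@@H](NS(=O)(=O)c2cc3ccnc(Cl)c3s2)CCN1Cc1cc2c[nH]ccc-2n1`, is the next member: a group of 10 heavy atoms (7 carbon, 1 nitrogen, 1 sulfur, 1 chlorine; one five-membered aromatic ring with 1 hetero atom, one six-membered aromatic ring with 1 hetero atom) in place of a group of 10 heavy atoms (7 carbon, 1 nitrogen, 1 sulfur, 1 chlorine; one five-membered aromatic ring with 1 hetero atom, one six-membered aromatic ring with 1 hetero atom), on a sulfonyl sulfur. For the measured compounds named here, both groups carry the chlorine, so the single measured step does not map onto this change directly; it shows only that the chlorine-bearing group in compound 2 sits well below the unsubstituted group in compound 1, and nothing is measured for a second chlorine-bearing isomer. The step of a number 10 percentage points higher from compound 2 to compound 3 (within the scatter) is therefore expected to be modest and upward, toward the number of compound 1 rather than past it, with wide uncertainty. Compound 3 is estimated at 45%, with a range from 20% to 68%.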

Compound 3, a percentage reported as inhibition, at one concentration (the size of the read-out at that concentration, not a potency): 25%
Estimate against measurement, compound 3: 20 percentage points above, and the stated range covers the measured number.
By their numbers in this assay, from the lowest: compounds 3 and 2 (each within the scatter of the next); then compound 1.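

Keeping the chlorine and joining the same atoms differently gives a number 10 percentage points lower from compound 2 to compound 3 (within the scatter), so this assay does not separate these two chlorine-bearing groups on the sulfonyl sulfur. Against the group without chlorine, the second chlorine-bearing group gives a number 36 percentage points lower from compound 1 to compound 3 (beyond the scatter), which matches the direction of a number 26 percentage points lower from compound 1 to compound 2 (beyond the scatter); both chlorine-bearing groups therefore sit clearly below compound 1 at this position, and no compound shown goes against this. No available evidence bears on the origin of this difference.

As far as these compounds go, whether the lower numbers belong to chlorine itself or would also follow from another substituent on this group remains open, for example a fluorine, a methyl group or an amine in place of the chlorine. From the compounds shown here alone, the shared core is also constant across all three compounds, so it is unknown whether the same ordering of groups on the sulfonyl sulfur would hold if the pyrrolidinone carbonyl or the group on its nitrogen were replaced, for example by a longer chain.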